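Will the Carboxyphenyl Swap Change Plasma Stability?

The compounds below may be only part of what the source reports. "The series", "measured", "known", "first", "only" and "open" are said of these compounds alone.

Compound 1 `Cc1cc(C(=O)O)ccc1OCCCCOc1ccc(C(=O)CC(C)C)c(O)c1C` gives 100%
Compound 2 `Cc1c(OCCCCOc2cccc(C(=O)O)c2)ccc(C(=O)CC2CCCC2)c1O` gives 99%
Compound 3 `Cc1c(OCCCCOc2cccc(C(=O)O)c2)ccc(C(=O)CC(C)C)c1O` gives 100%

These values come from an ADME assay on a cell-free system (plasma, Rattus norvegicus) for metabolic stability, read by LC-MS, with a stated time of 60 min, tested at 100 uM (on this read-out lower numbers stand for a less stable compound and higher numbers for a more stable compound), and lie within the scatter of one another, so compound 2 holds no distinct rank among the three. Compound 4 `Cc1cc(C(=O)O)ccc1OCCCCOc1ccc(C(=O)CC2CCCC2)c(O)c1C` differs from compound 2 in one place 4-carboxy-2-methylphenyl in place of 3-carboxyphenyl on an oxygen on a saturated carbon and carries 4-carboxy-2-methylphenyl in place of 3-carboxyphenyl on an oxygen on a saturated carbon. The closest evidence is the same swap in reverse, which gave no change at the digits printed from compound 1 to compound 3 (within the scatter) in compounds carrying isopropyl rather than cyclopentyl. The exchange of those two groups gave a number 1 percentage points higher from compound 2 to compound 3 (within the scatter) as well. Both steps are small, so no shift beyond the scatter is expected in this assay for this swap. The expected result is no change at the digits printed from compound 2 to compound 4 (within the scatter) and it would leave the value essentially unchanged. For compound 4 the estimated value is 99% with an expected range from 92% to 102% in this measurement.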

Compound 4, percent of the compound remaining: 99%
For compound 4 middle estimate and measured number coincide at the digits printed, and the stated range covers the measured number.
By their numbers in this assay, from the lowest: compounds 2, 4, 1 and 3 (each within the scatter of the next).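

With cyclopentyl on the chain, changing to 4-carboxy-2-methylphenyl gives no change at the digits printed from compound 2 to compound 4 (within the scatter), so the flat result seen with isopropyl also holds with a second chain group: the same change on two cores in this assay, no change at the digits printed (within the scatter) from compound 1 to compound 3 and no change at the digits printed (within the scatter) from compound 4 to compound 2, 0 percentage points apart, within the scatter of two such steps

With 4-carboxy-2-methylphenyl in place, the exchange of isopropyl for cyclopentyl gives a number 1 percentage points lower from compound 1 to compound 4 (within the scatter), which matches its outcome with 3-carboxyphenyl: the same change on two cores in this assay, a number 1 percentage points higher (within the scatter) from compound 2 to compound 3 and a number 1 percentage points higher (within the scatter) from compound 4 to compound 1, 0 percentage points apart, within the scatter of two such steps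

The four compounds now complete a square of single changes, and in this assay neither change moves the percent remaining beyond the scatter on either core.

Still open, going by these compounds, is whether a ring carrying an amine instead of the carboxylic acid, on the same oxygen, would match these results. A longer chain on the saturated chain carbon bound to the carbonyl carbon is equally untested by these compounds.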